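The source may report more compounds than this note shows. Statements on the series, on what has been measured and on what is new or still open speak of the compounds shown alone.

Compound 1 `CN1CCC[C@H]1[C@@H]1COc2c(N)cccc2O1` carries an amino group on the aromatic carbon of its shared core; in an assay on membranes from Cerebral cortex for displacement of a labelled ligand from Neuronal acetylcholine receptor; alpha4/beta2 (Rattus norvegicus), with a stated time of 5 min (a higher number here means a weaker inhibitor, a lower number a stronger inhibitor), compound 1 gives 7100 nM. Compound 2 `CN1CCC[C@H]1[C@@H]1COc2c(O)cccc2O1` differs only in that a hydroxy group stands where the amino group stood; in this assay compound 2 gives 550 nM. That single swap is a 13-fold lower number from compound 1 to compound 2 (1.11 log units; beyond the scatter), so compound 2 holds the lowest of the two numbers seen so far, with compound 1 as its nearest neighbour at a markedly higher number.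

Compound 3 `CN1CCC[C@H]1[C@@H]1COc2c(cccc2-c2ccccc2)O1` has not yet been measured. It is made from compound 2 by the change (phenyl in place of hydroxy on an aromatic carbon). For the measured compounds named here, the only measured step that touches the same place is the one from compound 1 to compound 2, where exchanging one small group for another moved the number by a large amount. For compound 3 a step of some size is therefore expected, but the data give no guide to its direction, since neither a phenyl nor a bare position at this carbon has been tested. Compound 3 is estimated to bind more weakly than compound 2, by a 5.5-fold higher number from compound 2 to compound 3 (0.74 log units; beyond the scatter), giving 3000 nM with a range from 400 nM to 20000 nM.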

Compound 3, inhibition constant: 640 nM
Compound 3: the middle estimate sits 4.7-fold (0.67 log units) above what was measured, within the range that was stated.
By their numbers in this assay, from the lowest: compounds 2 and 3 (each within the scatter of the next); then compound 1.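

In this assay, replacing the hydroxy with a phenyl gives a 1.2-fold higher number from compound 2 to compound 3 (0.07 log units; within the scatter), even though the entering group has 6 heavy atoms against 1 and brings a six-membered aromatic ring. This aromatic carbon therefore tolerates a much larger group in this series, and losing the hydrogen-bond donor and acceptor counted on the hydroxy brings no change beyond the scatter. The amino group now stands apart from both of the others, as replacing it with phenyl gives an 11-fold lower number from compound 1 to compound 3 (1.05 log units; beyond the scatter), so compound 1, and not compound 2 or compound 3, is the one with the clearly higher number.

From the compounds shown here alone, it remains open whether a bare aromatic carbon, a methoxy group, a carboxylic acid or a substituted phenyl at this carbon would stay close to compound 2 and compound 3 or move as far as compound 1 does. Nothing presented here accounts for the hydroxy and phenyl compounds giving such similar numbers, or for the amino compound differing from both.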